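A benzyl group on a compound at the limit

The source may hold more compounds than are shown below. What is called first, only, known or untested is meant among the compounds shown, and "the series" means these compounds.

In a functional assay on HCT-15 cells (Homo sapiens) for antiproliferative activity, read by MTT assay, with a stated time of 72 h (on this read-out lower numbers stand for stronger inhibition and higher numbers for weaker inhibition), compound 1 (`CCn1ccnc1-c1cc(OC)c(OC)c(OC)c1`) gives > 100000 nM as a limit. Compound 2 (`COc1cc(-c2nccn2CC(C)C)cc(OC)c1OC`) likewise gives > 100000 nM as a limit. Going by the values given here, the only measured step is a step that the two limits leave unreadable from compound 1 to compound 2 and so sets no size. The evidence stops at the limit of > 100000 nM in this assay, at which 2 of the 2 values shown sit, and offers no number to scale from. Compound 3 (`COc1cc(-c2nccn2Cc2ccccc2)cc(OC)c1OC`) carries phenyl in place of isopropyl on a saturated chain carbon bound to an aromatic nitrogen. With no readable step, at best a small gain toward stronger inhibition is expected in this assay for this change. Compound 3 is estimated at 80000 nM with an expected range from 15000 nM to 120000 nM in this read-out. The expected change is an at least 1.2-fold lower number from compound 2 to compound 3 (0.09 log units; that floor lies within the scatter) on this estimate.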

Compound 3, half-maximal inhibitory concentration: > 100000 nM
Compound 3: only a limit was reported; the forecaster's own chance of this, stated with the estimate: 65%; middle value at least 1.2-fold (0.09 log units) from the limit.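

Going by these compounds alone, compound 3 gives only a limit, as do compound 1 and compound 2, so no step among them can be read. The compounds shown leave open whether any group at this place gives a measurable value in this assay.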